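This account rests on a few compounds, and the source may have more. Where it says the series, first, only, none or still open, it means among the compounds named here.

Of the compounds shown here, three of a shared core have been measured in a functional assay on OVCAR-3 cells (Homo sapiens) for inhibition, read by sulforhodamine B assay, with a stated time of 48 h; on this read-out higher numbers stand for weaker inhibition of growth and lower numbers for stronger inhibition of growth. Compound 1 `Nc1cc(N)c2nc(-c3ccccc3)c(Oc3ccc(Cl)c(Cl)c3)nc2c1` gives 10700 nM in this assay. Compound 2 `CCOC(=O)[C@H](CCC(=O)O)NC(=O)c1ccc(CNc2nc3cc(N)cc(N)c3nc2-c2ccccc2)cc1` gives 49000 nM in this assay. Compound 3 `Nc1cc(N)c2nc(-c3ccccc3)c(NCc3ccc(Cl)c(Cl)c3)nc2c1` gives 2630 nM in this assay, the lowest of the three numbers; compound 1 stands closest to it, with a number higher by more than the usual scatter, and compound 2 stands furthest, also beyond the scatter. Compound 4 `COc1ccc(CNc2nc3cc(N)cc(N)c3nc2-c2ccccc2)cc1OC` has not yet been measured. It differs from compound 3 in one place: 3,4-dimethoxyphenyl in place of 3,4-dichlorophenyl on a saturated chain carbon bound to a nitrogen on an aromatic ring. Among the measured compounds shown here, no measured pair shows the effect of such an exchange on this core, so the expectation rests on the measured numbers and the structural change alone. The account expects the step of a 3.0-fold higher number from compound 3 to compound 4 (0.48 log units; beyond the scatter) in this assay to point toward weaker inhibition of growth, beyond the scatter but not by a large margin. For compound 4 the expected value in this assay is 8000 nM, with a range from 2500 nM to 30000 nM.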

Compound 4, concentration for 50% growth inhibition: 1320 nM
Compound 4: the middle estimate sits 6.1-fold (0.78 log units) above what was measured; the measured number lies below the stated range.
By their numbers in this assay, from the lowest: compounds 4 and 3 (each within the scatter of the next); then compound 1; then compound 2.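

In this assay the exchange of 3,4-dichlorophenyl for 3,4-dimethoxyphenyl on a saturated chain carbon bound to a nitrogen on an aromatic ring gives a 2.0-fold lower number from compound 3 to compound 4 (0.30 log units; within the scatter) and is the only one-place comparison shown on the shared core. At this position, the read-out does not separate the two groups, even though the entering group has 2 hydrogen-bond acceptors and the leaving group has 0, so for this pair the two chlorine atoms are not needed to keep growth inhibition at the level of compound 3. No measurement at hand explains why the two groups fall within the scatter of each other, so the result stands as an observation without an explanation.

The compounds shown leave open whether this holds for other groups on the same ring, such as an amine or a trifluoromethyl group, or for a phenyl ring with no group on it at all. They also leave open whether a longer chain in place of the single saturated chain carbon would keep the number of compound 4 or move it beyond the scatter.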